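One Group Exchanged on a Shared Core

The source may report more compounds than this note shows. Statements on the series, on what has been measured and on what is new or still open speak of the compounds shown alone.

- Compound 1 `COc1c(N2CCN(CN3C(=O)C(=O)c4ccccc43)CC2)c(F)cc2c(=O)c(C(=O)O)cn(C3CC3)c12`: 70800 nM
- Compound 2 `COc1c(N2CCN(CN3C(=O)C(=O)c4cc(F)ccc43)CC2)c(F)cc2c(=O)c(C(=O)O)cn(C3CC3)c12`: 70600 nM
- Compound 3 `COc1c(N2CCN(CN3C(=O)/C(=N\O)c4ccccc43)CC2)c(F)cc2c(=O)c(C(=O)O)cn(C3CC3)c12`: not yet measured

In an ADME assay on Vero cells (Chlorocebus sabaeus) for cytotoxicity, read by MTT assay, with a stated time of 72 h (on this read-out lower numbers stand for higher toxicity in this test and higher numbers for lower toxicity in this test), compound 2 gives 70600 nM, level with compound 1 within the scatter. Compound 3 differs from compound 2 as follows: a group of 12 heavy atoms (8 carbon, 2 nitrogen, 2 oxygen; one five-membered non-aromatic ring with 1 hetero atom, one six-membered aromatic ring of carbon only) in place of a group of 12 heavy atoms (8 carbon, 1 nitrogen, 2 oxygen, 1 fluorine; one five-membered non-aromatic ring with 1 hetero atom, one six-membered aromatic ring of carbon only), on a saturated chain carbon bound to an amine nitrogen in a ring. The exchange takes place on a saturated chain carbon bound to an amine nitrogen in a ring. Among the compounds with values here, the only measured step is a 1.0-fold lower number from compound 1 to compound 2 (0.00 log units; within the scatter), for fluoro in place of hydrogen on an aromatic carbon, and it stays within the scatter. Within the data shown here, no measured step tests the entering group, so the evidence is thin and the range must stay wide. The estimated change is a 1.1-fold lower number from compound 2 to compound 3 (0.04 log units; within the scatter), with no shift expected beyond the scatter in this assay. Compound 3 is expected at 65000 nM, within an estimated range of 30000 nM to 130000 nM.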

Compound 3, half-maximal cytotoxic concentration: 74400 nM
Beside the measured number, compound 3's estimate is 1.1-fold (0.06 log units) below it; the range from low to high includes it.
By their numbers in this assay, from the lowest: compounds 2, 1 and 3 (each within the scatter of the next).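

In this assay, the exchange on a saturated chain carbon bound to an amine nitrogen in a ring gives a 1.1-fold higher number from compound 2 to compound 3 (0.02 log units; within the scatter). Set against the group without fluoro, the same entering group gives a 1.1-fold higher number from compound 1 to compound 3 (0.02 log units; within the scatter). The earlier step tested only fluoro in place of hydrogen on an aromatic carbon, whereas these steps show that a group with 1 hydrogen-bond donor can stand at this place, where the leaving group has 0 hydrogen-bond donors, without a difference beyond the scatter in this assay.

From the compounds shown here alone, whether an amine, a carboxylic acid or a longer chain at this place would also stay within the scatter, or would give a difference beyond it, remains open. Nothing available explains why these three numbers lie within the scatter of one another.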